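A chloro group on compound 2

The compounds below may be only part of what the source reports. "The series", "measured", "known", "first", "only" and "open" are said of these compounds alone.

compound 1 `O=C(Nc1cc(-c2ccccn2)n[nH]1)N1CCC(c2cccc(F)c2)CC1` at 25.3 mL.min-1.g-1
compound 2 `O=C(Nc1cc(-c2ccccn2)n[nH]1)N1CCC(c2ccccc2)CC1` at 15.3 mL.min-1.g-1
compound 3 `O=C(Nc1cc(-c2ccccn2)n[nH]1)N1CCC(c2cccc(Cl)c2)CC1` not yet measured

These numbers come from an ADME assay on liver for metabolic stability, with Liver microsome (Homo sapiens) as the target, using microsomes (on this read-out higher numbers stand for fast clearance and lower numbers for slow clearance), where compound 2 at 15.3 mL.min-1.g-1 sits within the scatter of compound 1 at 25.3 mL.min-1.g-1 on this read-out. Compound 3 differs from compound 2 by chloro in place of hydrogen on an aromatic carbon with chloro in place of hydrogen on an aromatic carbon. For the measured compounds named here, the one measured step that bears on this is a 1.7-fold lower number from compound 1 to compound 2 (0.22 log units; within the scatter) with hydrogen in place of fluoro, and no measured step involves chloro itself. Given that small step, a change no larger than the scatter is expected, if anything toward a higher number. The expected change is a 1.7-fold higher number from compound 2 to compound 3 (0.23 log units; within the scatter) as estimated here. For compound 3 the estimate is 26 mL.min-1.g-1 with an expected range from 13 mL.min-1.g-1 to 50 mL.min-1.g-1 overall.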

Compound 3, intrinsic clearance in microsomes: 30.8 mL.min-1.g-1
For compound 3 the middle estimate is 1.2-fold (0.07 log units) below the measured one; the measured number falls inside the stated range.
By their numbers in this assay, from the lowest: compounds 2, 1 and 3 (each within the scatter of the next).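

Chloro on this aromatic carbon, in place of hydrogen, gives a 2.0-fold higher number from compound 2 to compound 3 (0.30 log units; within the scatter) in this assay, and chloro in place of fluoro gives a 1.2-fold higher number from compound 1 to compound 3 (0.09 log units; within the scatter). A second halogen has now been read at this place, and hydrogen, fluoro and chloro all stay within the scatter of one another on this read-out. Nothing available here accounts for these numbers. Still open, from the compounds shown here alone, is whether a methoxy group, a nitrile or an amine on this carbon would also stay within the scatter.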